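Free fraction: trifluoromethyl in place of cyano

This account rests on a few compounds, and the source may have more. Where it says the series, first, only, none or still open, it means among the compounds named here.

Measured in an ADME assay on a cell-free system (plasma, Homo sapiens); on this read-out higher numbers stand for a larger free fraction and lower numbers for a smaller free fraction
- compound 1 `CCc1c(CN2CC(C(=O)O)C2)cccc1-c1nsc(-c2ccc(OC(C)C)c(C(F)(F)F)c2)n1` gives 0.0026
- compound 2 `CCc1c(CCCC(=O)O)cccc1-c1nsc(-c2ccc(N3CCCCC3)c(C(F)(F)F)c2)n1` gives 0.00001
- compound 3 `CCc1c(CCCC(=O)O)cccc1-c1nsc(-c2ccc(OC(C)C)c(C#N)c2)n1` gives 0.0021

Compound 3, at 0.0021, lies within the scatter of compound 1 and far above compound 2. Compound 4 `CCc1c(CCCC(=O)O)cccc1-c1nsc(-c2ccc(OC(C)C)c(C(F)(F)F)c2)n1` carries trifluoromethyl in place of cyano on an aromatic carbon, ortho to an isopropoxy group (trifluoromethyl in place of cyano on an aromatic carbon). Among the measured compounds shown here, no matched pair for this change has been measured. Among the trifluoromethyl compounds, compound 2 gives 0.00001 and compound 1 gives 0.0026, and both differ from compound 3 elsewhere too, so the guidance is weak. A modest fall is expected, a 2.3-fold lower number from compound 3 to compound 4 (0.37 log units; beyond the scatter), with compound 1 arguing against a large one. Compound 4 is estimated at 0.0009 (range 0.0003 to 0.0024).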

Compound 4, unbound fraction: 0.00014
Beside the measured number, compound 4's estimate is 6.4-fold (0.81 log units) above it, outside the stated range (below it).
By their numbers in this assay, from the lowest: compound 2; then compound 4; then compounds 3 and 1 (each within the scatter of the next).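

On this assay the change at this aromatic carbon, ortho to an isopropoxy group, is large: trifluoromethyl in place of cyano gives a 15-fold lower number from compound 3 to compound 4 (1.18 log units; beyond the scatter). With trifluoromethyl held, the other two sites also matter: isopropoxy in place of piperidin-1-yl gives a 14-fold higher number from compound 2 to compound 4 (1.15 log units; beyond the scatter), and 2-carboxyethyl in place of 3-carboxyazetidin-1-yl gives a 19-fold lower number from compound 1 to compound 4 (1.27 log units; beyond the scatter). No measurement at hand accounts for these steps.

Open, as far as these compounds go, is whether the cyano gain holds alongside the 3-carboxyazetidin-1-yl or piperidin-1-yl groups. Also open, from the compounds shown here alone, is how chloro, methoxy or a primary amide would read at this carbon.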